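Aryl urea variation on a chloropyrazine scaffold

The source may report more compounds than this note shows. Statements on the series, on what has been measured and on what is new or still open speak of the compounds shown alone.

Two ureas sharing one core have been measured in a functional assay on HepG2 cells (Homo sapiens) for antiproliferative activity, read by MTT assay, with a stated time of 48 h; a lower number here means a stronger inhibitor, a higher number a weaker inhibitor. Compound 1 `Cc1ccc(NC(=O)Nc2cccc(CNc3nccnc3Cl)c2)c(C)c1` gives 9290 nM in this assay, the lowest of the two numbers. Compound 2 `CCc1ccc(NC(=O)Nc2cccc(CNc3nccnc3Cl)c2)c(CC)c1` carries diethyl in place of dimethyl on the terminal ring and gives 10800 nM in this assay, a number within the scatter of that of compound 1, so the two show no ordering.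

Compound 3 `O=C(Nc1cccc(CNc2nccnc2Cl)c1)Nc1ccc(Cl)cc1Br` has not yet been measured. It differs from compound 1 in one place: 2-bromo-4-chlorophenyl in place of 2,4-dimethylphenyl on an amide-type nitrogen. Within the data shown here, no measured pair shows this exchange, so the expectation rests on the two numbers alone. A step of a 1.5-fold lower number from compound 1 to compound 3 (0.19 log units; within the scatter) is expected, a modest gain that may not clear the scatter. In this assay compound 3 is therefore estimated at 6000 nM, with a range from 2000 nM to 18000 nM.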

Compound 3, half-maximal inhibitory concentration: 6720 nM
For compound 3 the middle estimate is 1.1-fold (0.05 log units) below the measured one; low and high end bracket the measured number.
By their numbers in this assay, from the lowest: compounds 3, 1 and 2 (each within the scatter of the next).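

In this assay, 2-bromo-4-chlorophenyl in place of 2,4-dimethylphenyl on an amide-type nitrogen gives a 1.4-fold lower number from compound 1 to compound 3 (0.14 log units; within the scatter) and so leaves the two compounds within the scatter of each other. The earlier pair differed only in methyl against ethyl on the terminal ring, whereas this result shows that bromine and chlorine can take the place of the two methyl groups without a difference that can be told from the scatter. No measurement at hand offers an explanation for this result.

As far as these compounds go, it remains open whether any terminal group at this nitrogen can move the number beyond the scatter, as all three compounds lie close together. A terminal ring carrying a carboxylic acid or an amine, or a terminal group without an aromatic ring, such as cyclohexyl, would test that.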